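Exchanging the ester group on a shared core

A few compounds are considered here, and "the series" means these few. Any claim that something is new, unique, unknown or untested is made for them only; others in the source may bear on it.

Measured compounds:
Compound 1, `Cc1nc(S(C)(=O)=O)ccc1Oc1ncnc(OC2CCN(C(=O)OC(C)(C)C#N)CC2)c1F`: 1320 nM
Compound 2, `Cc1nc(S(C)(=O)=O)ccc1Oc1ncnc(OC2CCN(C(=O)O[C@@H](C)CF)CC2)c1F`: 1680 nM
Compound 3, `CCC1(OC(=O)N2CCC(Oc3ncnc(Oc4ccc(S(C)(=O)=O)nc4C)c3F)CC2)CC1`: 333 nM

Compound 3 stands lowest of the three numbers in a functional assay on isolated protein for inhibition of Glucose-dependent insulinotropic receptor (Rattus norvegicus), read by HTRF and cAMP accumulation; on this read-out lower numbers stand for an effect already at smaller amounts and higher numbers for an effect only at larger amounts of compound. The step of a 4.0-fold lower number from compound 1 to compound 3 (0.60 log units; beyond the scatter) and the step of a 5.0-fold lower number from compound 2 to compound 3 (0.70 log units; beyond the scatter) both run downward, so compound 3 sits clearly apart from the other two, while the step of a 1.3-fold higher number from compound 1 to compound 2 (0.10 log units; within the scatter) keeps compounds 1 and 2 within the scatter of each other.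

Compound 4, `Cc1nc(S(C)(=O)=O)ccc1Oc1ncnc(OC2CCN(C(=O)OC3(C(F)(F)F)COC3)CC2)c1F`, is not yet measured. Its change from compound 3 is 3-(trifluoromethyl)oxetan-3-yl in place of 1-ethylcyclopropyl on an oxygen next to a carbonyl group. The two steps that bear on this change are those that brought the 1-ethylcyclopropyl group in, a 4.0-fold lower number from compound 1 to compound 3 (0.60 log units; beyond the scatter) and a 5.0-fold lower number from compound 2 to compound 3 (0.70 log units; beyond the scatter), each a modest step downward. Taking that group out again in favour of a different substituent on the same oxygen is expected to undo part of that gain, so a modest step upward, a 3.0-fold higher number from compound 3 to compound 4 (0.48 log units; beyond the scatter), is expected in this assay. Compound 4 is therefore estimated at 1000 nM, with a range from 300 nM to 3500 nM.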

Compound 4, half-maximal effective concentration: 342 nM
Compound 4: the middle estimate sits 2.9-fold (0.47 log units) above what was measured; low and high end bracket the measured number.
By their numbers in this assay, from the lowest: compounds 3 and 4 (each within the scatter of the next); then compounds 1 and 2 (each within the scatter of the next).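

In this assay, the 3-(trifluoromethyl)oxetan-3-yl group on the oxygen next to a carbonyl group matches the 1-ethylcyclopropyl group (a 1.0-fold higher number from compound 3 to compound 4 (0.01 log units; within the scatter)), so the low number at this position is not confined to one group, although the entering group has a four-membered ring with oxygen, three fluorines and a hydrogen-bond acceptor. The same group also stands clear of the two groups without a ring (a 4.9-fold lower number from compound 2 to compound 4 (0.69 log units; beyond the scatter); a 3.9-fold lower number from compound 1 to compound 4 (0.59 log units; beyond the scatter)), and among these four compounds both ring-bearing groups now sit apart from those two. No evidence is at hand on what lies behind this shared level.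

The compounds shown do not separate the oxetane ring from the trifluoromethyl group, which a plain oxetan-3-yl or a 1-(trifluoromethyl)cyclopropyl group could do. From the compounds shown here alone, how an amine or a carboxylic acid would fare on this oxygen also remains open.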